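Working notes: from compound 1 to compound 3

The source may report more compounds than this note shows. Statements on the series, on what has been measured and on what is new or still open speak of the compounds shown alone.

- compound 1 (`COc1cc(O)c(CC=C(C)C)c(O)c1C(=O)/C=C/c1cc(O)c(O)c(O)c1`) gives 30300 nM
- compound 2 (`COc1cc(O)c(C(=O)/C=C/c2ccc(O)cc2)c(OC)c1CC=C(C)C`) gives 25600 nM

Both values come from a functional assay on HeLa cells (Homo sapiens) for cytotoxicity, read by MTT assay; a lower number here means a stronger inhibitor, a higher number a weaker inhibitor. Compound 1 and compound 2 lie within the usual scatter of each other, so the two compounds mark a single level and give no order. For the measured compounds named here, compound 1 therefore stands at that shared level, and only two numbers are available to describe the series.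

The next compound to be read is compound 3 (`COc1cc(O)c(CC=C(C)C)c(O)c1C(=O)/C=C/c1ccccc1O`). It keeps the core of compound 1 and carries 2-hydroxyphenyl in place of 3,4,5-trihydroxyphenyl on a double-bonded chain carbon bound to a double-bonded chain carbon.

Going by the values given here, no measured pair differs in one place only, so the data give no direct guide to the size of this change. The estimate therefore starts from the level set by compound 1 (30300 nM) and stays wide. In this assay a small step is expected, leaning slightly towards a lower number and not clearly beyond the scatter (expected: a 1.4-fold lower number from compound 1 to compound 3 (0.16 log units; within the scatter)). Compound 3 is expected at 21000 nM (estimated range 8000 nM to 55000 nM).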

Compound 3, half-maximal inhibitory concentration: 5900 nM
Compound 3: the middle estimate sits 3.6-fold (0.55 log units) above what was measured; the measured number lies below the stated range.
By their numbers in this assay, from the lowest: compound 3; then compounds 2 and 1 (each within the scatter of the next).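

For the compounds shown here, this step is the first that changes one place only, and it shows that in this assay the group on a double-bonded chain carbon bound to a double-bonded chain carbon matters: 2-hydroxyphenyl in place of 3,4,5-trihydroxyphenyl gives a 5.1-fold lower number from compound 1 to compound 3 (0.71 log units; beyond the scatter) on an otherwise unchanged core. The entering group has fewer heavy atoms, fewer oxygen atoms and fewer hydrogen-bond donors and acceptors than the group it replaces, and this single pair cannot separate these differences from one another or from the particular arrangement of 2-hydroxyphenyl. No supporting data bear on why the number falls with this change.

A plain phenyl group, or a phenyl group carrying an amine or a carboxylic acid at this place, lies outside the compounds shown, so it remains open whether the lower number follows the loss of oxygen atoms or depends on 2-hydroxyphenyl itself. The compounds shown also leave open whether the same exchange would lower the number on the core of compound 2.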